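Swapping the pyridinyl-ethenyl arm for a chlorophenyl

The source may report more compounds than this note shows. Statements on the series, on what has been measured and on what is new or still open speak of the compounds shown alone.

Compound 2 `COC(=O)/C=C/c1cccc(N(Cc2ccc(/C=C/c3ccccn3)cc2)C(=O)C(C)C)c1` gives 310 nM in an assay on isolated protein with Bile acid receptor (Homo sapiens) as the target (a lower number here means that less compound is needed, a higher number that more compound is needed for the effect), which is the highest of the three numbers in hand. Its nearest neighbour is compound 1 `COC(=O)/C=C/c1cccc(N(Cc2ccc(/C=C/c3ccccn3)cc2)C(=O)C2CCCCC2)c1`, which gives 309 nM, so that a 1.0-fold higher number from compound 1 to compound 2 (0.00 log units; within the scatter); the difference between the two acyl groups leaves the number essentially unchanged. The furthest is compound 3 `COC(=O)/C=C/c1cccc(N(Cc2ccc(-c3ccc(F)c(F)c3)cc2)C(=O)C2CCCCC2)c1` with 72 nM.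

Compound 4 `COC(=O)/C=C/c1cccc(N(Cc2ccc(-c3cccc(Cl)c3)cc2)C(=O)C(C)C)c1` differs from compound 2 in one place: 3-chlorophenyl in place of 2-(pyridin-2-yl)ethenyl on an aromatic carbon. Within the data shown here, the step that speaks to this change is the one from compound 1 to compound 3, in which the same 2-(pyridin-2-yl)ethenyl arm gave way to a 3,4-difluorophenyl on the same aromatic carbon and a 4.3-fold lower number from compound 1 to compound 3 (0.63 log units; beyond the scatter). Because a 1.0-fold higher number from compound 1 to compound 2 (0.00 log units; within the scatter), the isopropyl carbonyl of compound 2 is not expected to alter how such an aryl replacement plays out. A 3-chlorophenyl is not a 3,4-difluorophenyl, so the transfer is uncertain, but a step of comparable direction and modest size is expected, that is a 3.1-fold lower number from compound 2 to compound 4 (0.49 log units; beyond the scatter).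

Compound 4 is therefore estimated to give about 100 nM in this assay, with a plausible range from 40 nM to 260 nM.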

Compound 4, half-maximal effective concentration: 77 nM
Compound 4: middle estimate off by 1.3-fold (0.11 log units), on the high side; the range from low to high includes it.
By their numbers in this assay, from the lowest: compounds 3 and 4 (each within the scatter of the next); then compounds 1 and 2 (each within the scatter of the next).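

With the cyclohexyl carbonyl, the swap away from the 2-(pyridin-2-yl)ethenyl arm had given a 4.3-fold lower number from compound 1 to compound 3 (0.63 log units; beyond the scatter); with the isopropyl carbonyl, this assay now gives a 4.0-fold lower number from compound 2 to compound 4 (0.60 log units; beyond the scatter) and the lower number is therefore no longer tied to a single acyl group or a single incoming aryl group. Across these two pairs, both 3,4-difluorophenyl and 3-chlorophenyl on this aromatic carbon come with a lower number than the arm they replace, a pattern that no listed pair goes against. The change removes the ring nitrogen and the double bond outside the aromatic rings together, so the result cannot assign the lower number to either one, and no measurement in hand offers an explanation for the step.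

Going by these compounds, it remains open whether an unsubstituted phenyl or a pyridin-2-yl on the same aromatic carbon would read like the chlorinated and fluorinated rings or like the original arm, which would help separate the role of the ring from that of its substituents. Also open, on these data alone, is how these aryl groups would behave if the methyl ester gave way to a carboxylic acid.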